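This account rests on a few compounds, and the source may have more. Where it says the series, first, only, none or still open, it means among the compounds named here.

Measured compounds in a functional assay on ECa-109 cells (Homo sapiens) for cytotoxicity, read by MTT assay, with a stated time of 72 h (on this read-out higher numbers stand for weaker inhibition and lower numbers for stronger inhibition), are these:
- compound 1 `CC(C)=C1C(=O)N(c2ccc(Cl)cc2)N(c2ccc(Cl)cc2)C1=O` gives 42100 nM
- compound 2 `CCC(C)=C1C(=O)N(c2ccc(Cl)cc2)N(c2ccc(Cl)cc2)C1=O` gives 41100 nM
- compound 3 `COc1cc(C=C2C(=O)N(c3ccc(Cl)cc3)N(c3ccc(Cl)cc3)C2=O)ccc1O` gives 7100 nM

Compound 3 holds the lowest of the three numbers (7100 nM), and its gaps to compound 1 and compound 2 lie beyond the scatter. Compound 4 `COc1ccc(C=C2C(=O)N(c3ccc(Cl)cc3)N(c3ccc(Cl)cc3)C2=O)cc1OC` differs from compound 3 by methyl in place of hydrogen on an oxygen on an aromatic ring as methyl in place of hydrogen on an oxygen on an aromatic ring, hydroxy to methoxy. Within the data shown here, the only measured step (a 1.0-fold lower number from compound 1 to compound 2 (0.01 log units; within the scatter)) lies within the scatter, but it sits on a saturated chain carbon and says little about this oxygen. Among the measured compounds shown here, no measured step covers this place in this assay so only a small step is expected, leaning uncertainly towards a higher number. The expected change is an estimate (a 1.4-fold higher number from compound 3 to compound 4 (0.15 log units; within the scatter)). Compound 4 is expected at 10000 nM (estimated range 4000 nM to 28000 nM).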

Compound 4, half-maximal inhibitory concentration: > 128000 nM
Compound 4: only a limit was reported (the forecaster's own chance of this, stated with the estimate: 3%); middle value at least 12-fold (1.10 log units) from the limit.
By their numbers in this assay, from the lowest: compound 3; then compounds 2 and 1 (each within the scatter of the next). At a limit, above all of these: compound 4.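

In this assay compound 4 gives > 128000 nM, which is a limit of the assay and not a number. The earlier compounds shown here said nothing about this oxygen, and it now proves sensitive: hydroxy to methoxy, a single methyl in place of hydrogen on an oxygen on an aromatic ring, gives an at least 18-fold higher number from compound 3 to compound 4 (1.25 log units; beyond the scatter). Among these compounds, the only earlier step, on a saturated chain carbon, gave a 1.0-fold lower number from compound 1 to compound 2 (0.01 log units; within the scatter).

From the compounds shown here alone, the full size of the new step remains unknown. Going by these compounds, it also remains open how this place would respond to an amine, a carboxylic acid or a longer chain on the oxygen.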